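Chloro substitution carried onto an amide-extended piperidine urea

The compounds below may be only part of what the source reports. "The series", "measured", "known", "first", "only" and "open" are said of these compounds alone.

The series rests on a shared core, carried in compound 1 `CCCCCN(CCCCC)C(=O)[C@H]1CCN(C(=O)N(c2ccccc2)c2ccccc2)[C@H](C(=O)O)C1`, whose acid is later converted into an extended amide. In an assay on CHO cells for binding affinity to Substance-P receptor (Homo sapiens) (on this read-out lower numbers stand for stronger inhibition and higher numbers for weaker inhibition), compound 1 gives 33 nM. Compound 2 `CCCCCN(CCCCC)C(=O)[C@H]1CCN(C(=O)N(c2ccccc2)c2cccc(Cl)c2)[C@H](C(=O)O)C1` differs from compound 1 by chloro in place of hydrogen on an aromatic carbon, and in this assay compound 2 gives 20 nM. The step of a 1.7-fold lower number from compound 1 to compound 2 (0.22 log units; within the scatter) is small and stays within the scatter, so the two acids cannot be set in order on this evidence.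

Compound 3 `CCCCCN(CCCCC)C(=O)[C@H]1CCN(C(=O)N(c2ccccc2)c2ccccc2)[C@H](C(=O)NCCN(CC(N)=O)Cc2ccccc2OC)C1` carries the extended amide in place of the acid; the difference between the core of compound 3 and the core of compound 1 is not broken down here. In this assay compound 3 gives 1.8 nM, the lowest of the three numbers, with compound 2 and compound 1 both standing beyond the scatter above it.

Compound 4 `CCCCCN(CCCCC)C(=O)[C@H]1CCN(C(=O)N(c2ccccc2)c2cccc(Cl)c2)[C@H](C(=O)NCCN(CC(N)=O)Cc2ccccc2OC)C1` is made from compound 3 by chloro in place of hydrogen on an aromatic carbon. This is the same change as that from compound 1 to compound 2, made at the same place on the same ring. Because a 1.7-fold lower number from compound 1 to compound 2 (0.22 log units; within the scatter) stayed within the scatter, the step from compound 3 to compound 4 is expected to be of like size, a 1.4-fold lower number from compound 3 to compound 4 (0.14 log units; within the scatter). For compound 4 in this assay the expected value is 1.3 nM, with a range from 0.5 nM to 4 nM.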

Compound 4, half-maximal inhibitory concentration: 3.8 nM
For compound 4 the middle estimate is 2.9-fold (0.47 log units) below the measured one; the measured number falls inside the stated range.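

In this assay, chloro in place of hydrogen on the extended amide gives a 2.1-fold higher number from compound 3 to compound 4 (0.32 log units; beyond the scatter), a modest step that does not repeat the small one seen on the acids. Set side by side, the two steps differ, so the size of the change measured on the core of compound 1 did not carry over unchanged to the core of compound 3: the same change on two cores in this assay, a 1.7-fold lower number (0.22 log units; within the scatter) from compound 1 to compound 2 and a 2.1-fold higher number (0.32 log units; beyond the scatter) from compound 3 to compound 4, 3.5-fold (0.54 log units) apart, beyond the scatter of two such steps. This rests on a single pair of cores and a single assay, and since the step on the acids lies within the scatter, it shows that the chloro change depends on its core here, but neither how general that dependence is in the series nor which part of the extended amide is responsible.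

The compounds shown leave open whether fluoro or methyl in place of the same hydrogen, or chloro at another place on the ring, would follow the same course on the two cores. They also leave open whether a primary amide or a shorter chain in place of the extended amide would behave like the acids or like compound 3.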